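Aryl swap on the amide nitrogen of compound 3

The compounds below may be only part of what the source reports. "The series", "measured", "known", "first", "only" and "open" are said of these compounds alone.

Compound 1 `O=C(CN1CCN(c2nnc(Cc3ccncc3)c3ccccc23)CC1)Nc1ccc(F)c(Cl)c1`: 4 nM
Compound 2 `O=C(CN1CCN(c2nnc(Cc3ccncc3)c3ccccc23)CC1)Nc1ccc(Br)cc1`: 19 nM
Compound 3 `Cc1ccc(F)cc1NC(=O)CN1CCN(c2nnc(Cc3ccccc3)c3ccccc23)CC1`: 19200 nM

In a functional assay on MDA-MB-231 cells (Homo sapiens) for cytotoxicity, read by MTT assay, with a stated time of 72 h (on this read-out higher numbers stand for weaker inhibition and lower numbers for stronger inhibition), compound 3 gives the highest number of the three measured compounds. Compound 2 lies nearest to it, and compound 1 lies furthest away, both far beyond the scatter. Compound 3 also differs from compounds 1 and 2 at more than one place, so its two gaps cannot be read as single steps.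

Compound 4 `COc1ccc(NC(=O)CN2CCN(c3nnc(Cc4ccccc4)c4ccccc34)CC2)cc1OC` differs from compound 3 by 3,4-dimethoxyphenyl in place of 5-fluoro-2-methylphenyl on an amide-type nitrogen. For the measured compounds named here, the one measured step that touches the same position, a 4.8-fold higher number from compound 1 to compound 2 (0.68 log units; beyond the scatter), is a modest one, and it involves neither of the two groups in question; no measured step bears directly on this change. The account therefore expects compound 4 to stay in the region of compound 3, with a 1.3-fold lower number from compound 3 to compound 4 (0.11 log units; within the scatter), and the direction is uncertain. Compound 4 is estimated at 15000 nM, with a range from 3000 nM to 60000 nM.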

Compound 4, half-maximal inhibitory concentration: 32200 nM
Beside the measured number, compound 4's estimate is 2.1-fold (0.33 log units) below it; the measured number falls inside the stated range.
By their numbers in this assay, from the lowest: compound 1; then compound 2; then compounds 3 and 4 (each within the scatter of the next).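

In this assay, the step of a 1.7-fold higher number from compound 3 to compound 4 (0.22 log units; within the scatter) shows that, on the core of compound 3, exchanging 5-fluoro-2-methylphenyl for 3,4-dimethoxyphenyl on the amide-type nitrogen leaves the two compounds indistinguishable. The earlier step of a 4.8-fold higher number from compound 1 to compound 2 (0.68 log units; beyond the scatter) showed that a swap at this position can register on the core of compound 1, whereas this swap does not, even though the entering group brings hydrogen-bond acceptors that the leaving group lacks.

The compounds shown leave open whether a quite different group on this nitrogen, such as an aryl ring bearing a carboxylic acid or an amine, would shift the number on the core of compound 3. They also cannot separate the aryl group's share from that of the other difference in the large gap to compounds 1 and 2. No available evidence accounts for this result.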